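From a Methyl Ester to a Nitro-Substituted Acid

The compounds below may be only part of what the source reports. "The series", "measured", "known", "first", "only" and "open" are said of these compounds alone.

Compound 1 `COC(=O)c1ccc(CN2CCC[C@H](O[C@H](CO)c3cc(Cl)cc(Cl)c3)[C@@H]2c2ccccc2)c(C)c1` gives 900 nM in an assay on isolated protein for activation of cGMP-dependent protein kinase 1 (Homo sapiens), read by ADP-Glo, with stated times of 30 min and 2 h, in the presence of a further agent that is not named here; on this read-out lower numbers stand for an effect already at smaller amounts and higher numbers for an effect only at larger amounts of compound.
Compound 2 `Cc1cc(C(=O)O)ccc1CN1CCC[C@@]2(C[C@@H](c3ccccc3)CO2)[C@@H]1c1ccccc1` gives 43000 nM in this assay.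
Compound 3 `Cc1cc(C(=O)O)ccc1CN1CCC[C@H](O[C@H](CO)c2cc(Cl)cc(Cl)c2)[C@@H]1C1CCCCC1` gives 65000 nM in this assay.

Compound 1 has the lowest number of the three, and its distance to compound 2 and to compound 3 lies beyond the scatter of this assay. Compound 4 `O=C(O)c1ccc(CN2CCC[C@H](O[C@H](CO)c3cc(Cl)cc(Cl)c3)[C@@H]2c2ccccc2)c([N+](=O)[O-])c1` is not yet measured; it differs from compound 1 in this way: a group of 12 heavy atoms (7 carbon, 1 nitrogen, 4 oxygen; one six-membered aromatic ring of carbon only) in place of a group of 11 heavy atoms (9 carbon, 2 oxygen; one six-membered aromatic ring of carbon only), on a saturated chain carbon bound to an amine nitrogen in a ring. Among the measured compounds shown here, no pair of measured compounds isolates this change. Compound 2 and compound 3 carry a free carboxylic acid and give high numbers, yet each also differs from compound 1 elsewhere, so they only hint. The step from compound 1 to compound 4 in this assay is expected to be a 3.3-fold higher number from compound 1 to compound 4 (0.52 log units; beyond the scatter), toward a higher number. Compound 4 is estimated at 3000 nM, within 500 nM to 20000 nM.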

Compound 4, half-maximal effective concentration: 520 nM
Compound 4: middle estimate off by 5.8-fold (0.76 log units), on the high side; low and high end bracket the measured number.
By their numbers in this assay, from the lowest: compounds 4 and 1 (each within the scatter of the next); then compounds 2 and 3 (each within the scatter of the next).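

In this assay, placing 4-carboxy-2-nitrophenyl on the saturated chain carbon bound to an amine nitrogen in a ring gives a 1.7-fold lower number from compound 1 to compound 4 (0.24 log units; within the scatter) and this lies within the scatter. A free carboxylic acid together with a nitro group is therefore tolerated here on the core of compound 1, which compound 2 and compound 3 could not show, since each differs elsewhere as well. No measurement at hand explains this result.

The compounds shown do not separate the ester-to-acid change from the methyl-to-nitro change, so the contribution of each stays open. As far as these compounds go, whether an amide in place of the carboxylic acid, or a nitrile in place of the nitro group, would fit equally well also stays open.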